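Amide Nitrogen: From Isobutyl to 2-Methoxyphenyl

This account rests on a few compounds, and the source may have more. Where it says the series, first, only, none or still open, it means among the compounds named here.

Compound 1 `C=CC1=C(C(=O)NCc2ccccc2)C(c2ccc(OC)cc2)OC1`: > 100000 nM
Compound 2 `C=CC1=C(C(=O)NCCC)C(c2ccc(Cl)c(Cl)c2)OC1`: > 100000 nM
Compound 3 `C=CC1=C(C(=O)NCC(C)C)C(c2ccc(Cl)c(Cl)c2)OC1`: > 100000 nM

For the measured compounds named here, every value so far in a functional assay on A549 cells (Homo sapiens) for cytotoxicity, read by MTT assay, with a stated time of 24 h (on this read-out higher numbers stand for weaker inhibition and lower numbers for stronger inhibition), is a limit of the assay rather than a number. Compound 3 sits at that limit, as described by the limit of > 100000 nM in this assay, at which 3 of the 3 values shown sit. Going by the values given here, the one measured step, a step that the two limits leave unreadable from compound 2 to compound 3, cannot be read because both ends are limits. Compound 4 `C=CC1=C(C(=O)Nc2ccccc2OC)C(c2ccc(Cl)c(Cl)c2)OC1` carries the change (2-methoxyphenyl in place of isobutyl on an amide-type nitrogen), that is, 2-methoxyphenyl in place of isobutyl on an amide-type nitrogen. Among the compounds with values here, no measured step bears on this change, so the step of a number no higher from compound 3 to compound 4 (the limit leaves the size open) is expected to be of no readable size. Compound 4 is therefore estimated at 100000 nM in this assay, in a range from 30000 nM to 300000 nM, most likely again reported as a limit.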

Compound 4, half-maximal inhibitory concentration: > 100000 nM
Compound 4: a limit, no number; the forecaster's own chance of this, stated with the estimate: 80%; the middle value lies on the limit itself.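

Compound 4 also gives only a limit, not a number, so the steps to it from compound 2 and from compound 3 cannot be read: the limit of > 100000 nM in this assay, at which 4 of the 4 values shown sit. The compounds shown leave open whether any group on the amide-type nitrogen changes the cytotoxicity at all.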